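Salicylanilide series, cytotoxicity on lung cells

A few compounds are considered here, and "the series" means these few. Any claim that something is new, unique, unknown or untested is made for them only; others in the source may bear on it.

Among the compounds with values here, compound 3 `CC(C)Nc1ccc(NC(=O)c2cc(Cl)ccc2O)c(Cl)c1` is the only member of the set with a number so far. In an ADME assay on A549 cells (Homo sapiens) for cytotoxicity, read by LDH release, with a stated time of 15 h (on this read-out lower numbers stand for higher toxicity in this test and higher numbers for lower toxicity in this test), compound 3 gives 82700 nM. Within the data shown here, compound 1 `O=C(Nc1ccc(N2CCCC2)cc1Cl)c1cc(Cl)ccc1O` is recorded in this assay as "not determined" (no result reported), and compound 2 `O=C(Nc1ccc(NCCCO)cc1Cl)c1cc(Cl)ccc1O` is recorded in this assay as "not determined" (no result reported), so compound 3 stands alone and no step between measured compounds can be read from the series. Compound 4 `O=C(Nc1ccc(NCc2ccccc2)cc1Cl)c1cc(Cl)ccc1O` is not yet measured. It differs from compound 3 in one place: benzyl in place of isopropyl on a nitrogen on an aromatic ring. Without a measured step of the same kind to lean on, the expected change in this assay is a modest move toward a lower number, at or just beyond the usual scatter, estimated as a 1.8-fold lower number from compound 3 to compound 4 (0.26 log units; within the scatter). For compound 4 the value in this assay is estimated at 45000 nM, with a range from 18000 nM to 110000 nM.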

Compound 4, half-maximal cytotoxic concentration: 81300 nM
For compound 4 the middle estimate is 1.8-fold (0.26 log units) below the measured one; the measured number falls inside the stated range.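

Benzyl in place of isopropyl on a nitrogen on an aromatic ring gives a 1.0-fold lower number from compound 3 to compound 4 (0.01 log units; within the scatter) in this assay. This first readable step shows that, for this one pair, the six-membered aromatic ring entering with benzyl does not move the number beyond the scatter. Nothing available here gives a reason for this result.

Steps to compound 1 and compound 2 cannot be read. Open, going by these compounds, is how a carboxylic acid or a morpholine on this nitrogen, or a longer chain ending in either, would read in this assay.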